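A few compounds are considered here, and "the series" means these few. Any claim that something is new, unique, unknown or untested is made for them only; others in the source may bear on it.

Measured in an in vivo ADME assay on the whole organism (plasma) for pharmacokinetics, with Rattus norvegicus as the target, at a dose of 50 mg/kg by the oral route; on this read-out lower numbers stand for lower exposure and higher numbers for higher exposure at the dose given:
- compound 1 `Cc1cc(C)c(NC(=O)c2sccc2S(=O)(=O)Nc2onc(C)c2Cl)c(C)c1`: 81600 nM
- compound 2 `CC(=O)OCc1c(C)cc(C)c(NC(=O)c2sccc2S(=O)(=O)Nc2onc(C)c2Cl)c1C`: 7420 nM

Going by the values given here, of these two, compound 2 stands lowest, at 7420 nM, and its only neighbour, compound 1, gives 81600 nM. Compound 3 `Cc1cc(C)c(OC2CC2)c(C)c1NC(=O)c1sccc1S(=O)(=O)Nc1onc(C)c1Cl` differs from compound 2 in one place, with cyclopropyloxy in place of acetoxymethyl on an aromatic carbon. Among the compounds with values here, only one measured step bears on this: an 11-fold lower number from compound 1 to compound 2 (1.04 log units; beyond the scatter), a large step in which acetoxymethyl entered in place of hydrogen. Within the data shown here, compound 3 no longer carries that acetoxymethyl, but no measured compound carries cyclopropyloxy, so only part of that step is expected to return in this assay. The estimated change is a 2.4-fold higher number from compound 2 to compound 3 (0.38 log units; beyond the scatter), a moderate rise. For compound 3 the estimate is 18000 nM, with an expected range of 4000 nM to 75000 nM.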

Compound 3, maximal plasma concentration: 12300 nM
The estimate for compound 3 lay 1.5-fold (0.17 log units) above the measured number, within the range that was stated.
By their numbers in this assay, from the lowest: compounds 2 and 3 (each within the scatter of the next); then compound 1.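

In this assay, exchanging acetoxymethyl for cyclopropyloxy on this aromatic carbon gives a 1.7-fold higher number from compound 2 to compound 3 (0.22 log units; within the scatter), so the two groups cannot be told apart on this read-out. Set against hydrogen at the same position, cyclopropyloxy gives a 6.6-fold lower number from compound 1 to compound 3 (0.82 log units; beyond the scatter), which shows that the drop seen earlier as an 11-fold lower number from compound 1 to compound 2 (1.04 log units; beyond the scatter) is not confined to acetoxymethyl, since two groups with different atoms and with or without a ring both read well under compound 1. Nothing measured here gives a reason for this.

As far as these compounds go, whether methoxy, an amine or a carboxylic acid on this carbon would read like compound 2 and compound 3 or like compound 1 remains open. Also open, from the compounds shown here alone, is which feature of the two groups the step away from hydrogen depends on.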